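Amide-heteroaryl swap on the piperidinylsulfonyl benzylamide series

A few compounds are considered here, and "the series" means these few. Any claim that something is new, unique, unknown or untested is made for them only; others in the source may bear on it.

Measured compounds:
compound 1 `O=C(NCc1ccc(S(=O)(=O)N2CCCCC2)cc1)c1cnc2nccn2c1` gives 3 nM
compound 2 `O=C(NCc1ccc(S(=O)(=O)c2cc(F)cc(F)c2)cc1)c1cnc2nccn2c1` gives 2 nM
compound 3 `O=C(NCc1ccc(S(=O)(=O)c2cccc(C(F)(F)F)c2)cc1)c1cnc2nccn2c1` gives 1 nM

All three values come from an assay for inhibition of Nicotinamide phosphoribosyltransferase (Homo sapiens), read by mass spectrometry, with stated times of 15 min and 30 min; on this read-out higher numbers stand for weaker inhibition and lower numbers for stronger inhibition. Compound 1 sits at the highest of the three numbers. The gap to compound 2 is a 1.5-fold lower number from compound 1 to compound 2 (0.18 log units; within the scatter), and the gap to compound 3 is a 3.0-fold lower number from compound 1 to compound 3 (0.48 log units; beyond the scatter); between compound 2 and compound 3 the step is a 2.0-fold lower number from compound 2 to compound 3 (0.30 log units; within the scatter). Every one of these steps changes only the group on the sulfonyl sulfur, while the amide side of the shared core is held fixed.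

Compound 4 `O=C(NCc1ccc(S(=O)(=O)N2CCCCC2)cc1)c1cc2ccncc2o1` keeps the piperidin-1-yl sulfonyl of compound 1 and instead alters the amide side: a group of 9 heavy atoms (7 carbon, 1 nitrogen, 1 oxygen; one five-membered aromatic ring with 1 hetero atom, one six-membered aromatic ring with 1 hetero atom) in place of a group of 9 heavy atoms (6 carbon, 3 nitrogen; one five-membered aromatic ring with 2 hetero atoms, one six-membered aromatic ring with 2 hetero atoms), on a carbonyl carbon. Among the measured compounds shown here, none of the measured steps touches this position, so the three steps give no direct read on the size or direction of the change; they only show that the sulfonyl-side variations moved this assay modestly at most. With no measured guide at the carbonyl carbon, the expectation is anchored on compound 1 with a wide range, allowing for either a small loss or a retained value.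

Compound 4 is estimated at 8 nM, with a range from 2 nM to 40 nM. The step this estimate implies is a 2.7-fold higher number from compound 1 to compound 4 (0.43 log units; beyond the scatter), expected rather than measured.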

Compound 4, half-maximal inhibitory concentration: 40 nM
The estimate for compound 4 lay 5.0-fold (0.70 log units) below the measured number; measured number inside the range.
By their numbers in this assay, from the lowest: compounds 3, 2 and 1 (each within the scatter of the next, the first and the last beyond it); then compound 4.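

In this assay, among the compounds shown here, the change on the carbonyl carbon gives the largest step so far: a 13-fold higher number from compound 1 to compound 4 (1.12 log units; beyond the scatter). The largest step on the sulfonyl side is a 3.0-fold lower number from compound 1 to compound 3 (0.48 log units; beyond the scatter), so among the compounds shown, this single swap at the carbonyl carbon moves the number further than any change of the group on the sulfonyl sulfur, even though the leaving and entering groups both hold 9 heavy atoms and both combine a five-membered with a six-membered aromatic ring. The two groups differ in their hetero atoms and hydrogen-bond acceptors, but nothing measured here bears on which of these differences, if either, accounts for the step.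

Going by these compounds, compound 4 carries only the piperidin-1-yl sulfonyl, so it remains open whether the same loss would appear with 3,5-difluorophenyl or 3-(trifluoromethyl)phenyl on the sulfonyl sulfur. Also open, on these data alone, are whether the loss follows the oxygen or the arrangement of the nitrogens in the entering group, and whether an amine or a methoxy group on that group would change the number in this assay.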